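The source may hold more compounds than are shown below. What is called first, only, known or untested is meant among the compounds shown, and "the series" means these compounds.

Measured so far:
Compound 1, `ClCc1cccc(Cn2cnc3c(Cl)nc(Cl)nc32)c1`, 3380 nM
Compound 2, `ClCc1ccccc1Cn1cnc2ncnc(Cl)c21`, 1650 nM
Compound 3, `ClCc1cccc(Cn2cnc3nc(Cl)nc(Cl)c32)c1`, 1040 nM

Three compounds have been characterised in a functional assay on MOLT-4 cells (Homo sapiens) for cytotoxicity, read by sulforhodamine B assay, with a stated time of 48 h; a lower number here means a stronger inhibitor of growth, a higher number a weaker inhibitor of growth. Compound 1 gives 3380 nM, compound 2 gives 1650 nM and compound 3 gives 1040 nM. Compound 2 stands second highest of the three numbers. Its nearest neighbour is compound 3, whose number is lower by a margin that lies within the usual scatter of this assay, so no order between compound 2 and compound 3 can be claimed. Compound 1 stands furthest from compound 2, with a higher number, and that gap is just beyond the scatter.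

The next compound to be tested is compound 4, `ClCc1ccccc1Cn1cnc2nc(Cl)nc(Cl)c21`. Compared with compound 2 it carries chloro in place of hydrogen on an aromatic carbon. Going by the values given here, no pair of measured compounds differs by exactly this change, so the size of the step has to be judged from the values alone. Compound 3, which carries two chloro groups on its core, gives 1040 nM, a number somewhat lower than that of compound 2, but the difference is within the scatter. The step from compound 2 to compound 4 is therefore expected to be small, towards a lower number at most, and likely within the scatter, as a 1.4-fold lower number from compound 2 to compound 4 (0.14 log units; within the scatter). Compound 4 is expected to give about 1200 nM in this assay, with a plausible range from 500 nM to 3000 nM.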

Compound 4, concentration for 50% growth inhibition: 1340 nM
Compound 4: the middle estimate sits 1.1-fold (0.05 log units) below what was measured; measured number inside the range.
By their numbers in this assay, from the lowest: compounds 3, 4 and 2 (each within the scatter of the next); then compound 1.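

Going by these compounds alone, this gives the first readable one-place step in this assay: chloro in place of hydrogen on an aromatic carbon, between two ring nitrogen atoms, gives (a 1.2-fold lower number from compound 2 to compound 4 (0.09 log units; within the scatter)). At this position of the shared core, compound 2 with hydrogen and compound 4 with chloro cannot be ordered, so this single exchange shows no effect that can be told apart from the usual variation between repeated measurements. Nothing measured here offers an explanation for this result, and no independent data bear on it.

The compounds shown leave open whether an amine or a methoxy group on this same aromatic carbon would give a step beyond the scatter, so the tolerance seen here can be claimed for chloro alone. Within the data shown here, they also leave open whether chloro in place of hydrogen at this position would give a similarly small step with the chloromethyl group placed as it is in compound 3, since that compound has no counterpart carrying hydrogen at this position.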